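The source may hold more compounds than are shown below. What is called first, only, known or untested is meant among the compounds shown, and "the series" means these compounds.

Measured in a functional assay on the whole organism (Tail, strain ICR) with Mus musculus as the target, in the tail flick test, with a stated time of 120 min, at a dose of 25 umol/kg by the oral route; a lower number here means a weaker effect, a higher number a stronger effect of the compound at the dose given:
compound 1, `O=C(CN(c1ncnc2c1ncn2C1CCCCO1)C1CC1)N[C@@H](CO)C(=O)OCc1ccccc1`, gives 29.2%
compound 2, `C[C@@H](O)[C@H](NC(=O)CN(c1nc(Cl)nc2[nH]cnc12)C1CC1)C(=O)O`, gives 37.6%

On the numbers as written compound 1 sits at the lower end of the pair, but the gap to compound 2 is within the scatter, so the two read as one level rather than as an order. For the measured compounds named here, no step between measured compounds that differ in one place is available, so nothing recorded here tells how much a single change of this kind moves the read-out.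

Compound 3, `C[C@H](NC(=O)CN(c1ncnc2c1ncn2C1CCCCO1)C1CC1)C(=O)OCc1ccccc1`, has not yet been measured. It differs from compound 1 by hydrogen in place of hydroxy on a saturated chain carbon, two bonds along the chain from an amide-type nitrogen and a carbonyl carbon. Going by the values given here, with no measured step of this sort to lean on, the expectation in this assay is a step of no more than the usual scatter, with no direction preferred; the estimated step of a number 0.8 percentage points higher from compound 1 to compound 3 (within the scatter) states that. Compound 3 is accordingly expected to give 30%, in the range 15% to 48%.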

Compound 3, a percentage reported as activity, at one dose (the size of the read-out at that dose, not a potency): 25.3%
Compound 3: the middle estimate sits 4.7 percentage points above what was measured, within the range that was stated.
By their numbers in this assay, from the lowest: compounds 3, 1 and 2 (each within the scatter of the next, the first and the last beyond it).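

In this assay, for the compounds shown here, this is the first step that can be read for a single change: a number 3.9 percentage points lower from compound 1 to compound 3 (within the scatter). Replacing hydroxymethyl with methyl at this position, on a saturated chain carbon, therefore leaves the read-out at one level, so at this dose and time the hydroxy is not required to keep it there. Nothing available explains the size of this step.

On these data alone, whether an amine or a longer chain in place of the hydroxymethyl would move the read-out beyond the scatter remains open. As far as these compounds go, it is also open whether the same exchange would give a similar step on a different core, or at another dose or time.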